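Swapping Fluoro for Azido on Two Nucleoside Cores

A few compounds are considered here, and "the series" means these few. Any claim that something is new, unique, unknown or untested is made for them only; others in the source may bear on it.

Compound 1 `Nc1ccnc2c1ncn2[C@@H]1O[C@H](CO)[C@](O)(CF)[C@H]1O` and compound 3 `[N-]=[N+]=NC[C@@]1(O)[C@@H](CO)O[C@@H](n2cnc3c(N)ccnc32)[C@@H]1O` share one core, while compound 2 `Nc1ccn([C@@H]2O[C@H](CO)[C@](O)(CF)[C@H]2O)c(=O)n1` and the still unmeasured compound 4 `[N-]=[N+]=NC[C@@]1(O)[C@@H](CO)O[C@@H](n2ccc(N)nc2=O)[C@@H]1O` share another; the difference between the two cores is not broken down here.

In an ADME assay on Huh-7 cells (Homo sapiens) for cytotoxicity, read by WST assay, with a stated time of 3 days (a higher number here means that more compound is tolerated, a lower number that less compound is tolerated), compound 1 gives > 100000 nM, which is a limit of the assay rather than a number. In this assay compound 2 gives > 100000 nM, also a limit. Compound 3 gives > 100000 nM, again a limit. The change from compound 1 to compound 3 is azido in place of fluoro on a saturated chain carbon bound to a saturated ring carbon and made a step that the two limits leave unreadable from compound 1 to compound 3. The same change, at the same place, carries compound 2 to compound 4: azido in place of fluoro on a saturated chain carbon bound to a saturated ring carbon. Whether it moves cytotoxicity cannot be read, because the limit of > 100000 nM in this assay, at which 3 of the 3 values shown sit, hides any movement. Compound 4 is therefore expected to stay at that limit, around 150000 nM. The step this expectation means is a step that the limit leaves unreadable from compound 2 to compound 4.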

Compound 4, half-maximal cytotoxic concentration: 300 nM
For compound 4 the middle estimate is 500-fold (2.70 log units) above the measured one, and the stated range ends above it.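

In this assay, replacing fluoromethyl with azidomethyl on the core of compound 2 gives an at least 330-fold lower number from compound 2 to compound 4 (2.52 log units; beyond the scatter). The same change on the core of compound 1 leads to compound 3, which gives > 100000 nM, a limit of the assay and not a number. The large drop in tolerated concentration therefore does not carry over as a readable result from one core to the other, and the size of any step on the core of compound 1 stays unknown because the values there sit at a limit: the limit of > 100000 nM in this assay, at which 3 of the 4 values shown sit.

The compounds shown leave open which feature of the two cores separates these outcomes. They also leave open whether another group in the same place, such as aminomethyl, would lower the number on either core.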